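Compound 2 and a chloro change in growth inhibition

The compounds below may be only part of what the source reports. "The series", "measured", "known", "first", "only" and "open" are said of these compounds alone.

Values so far in a functional assay on OVCAR-3 cells (Homo sapiens) for inhibition, read by sulforhodamine B assay, with a stated time of 48 h (a lower number here means a stronger inhibitor of growth, a higher number a weaker inhibitor of growth), for the three measured compounds:
Compound 1 `CC(C)(C)NCc1c(C(=O)O)nn(-c2ccccc2)c1-c1ccccc1` gives > 716000 nM as a limit
Compound 2 `Cc1ccc(-c2c(CNC(C)(C)C)c(C(=O)O)nn2-c2ccccc2)cc1` gives 283000 nM as a number
Compound 3 `COc1ccc(-c2c(CNC(C)(C)C)c(C(=O)O)nn2-c2ccccc2)cc1` gives > 659000 nM as a limit

Going by the values given here, compound 2 holds the only true number of the three and is the strongest of them, though still weak in absolute terms. Compound 4 `Cc1ccc(-c2c(CNC(C)(C)C)c(C(=O)O)nn2-c2ccc(Cl)cc2)cc1` differs from compound 2 by one change chloro in place of hydrogen on an aromatic carbon in which chloro takes the place of hydrogen on an aromatic carbon, turning phenyl into 4-chlorophenyl. Among the compounds with values here, no measured step adds chloro or alters this ring, so the evidence is indirect. Methyl in place of hydrogen gave an at least 2.5-fold lower number from compound 1 to compound 2 (0.40 log units; beyond the scatter) and methoxy in place of methyl gave an at least 2.3-fold higher number from compound 2 to compound 3 (0.36 log units; beyond the scatter) so small groups on an aromatic carbon can shift this assay in either direction. A modest drop seems the likeliest outcome, with little confidence. The expected move is a 2.2-fold lower number from compound 2 to compound 4 (0.34 log units; beyond the scatter) and it remains only an estimate. For compound 4 the estimated value is 130000 nM with an expected range from 45000 nM to 400000 nM in this assay.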

Compound 4, concentration for 50% growth inhibition: > 629000 nM
Compound 4: no number, only a limit; the forecaster's own chance of this, stated with the estimate: 15%; middle value at least 4.8-fold (0.68 log units) away from the limit.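

Turning phenyl into 4-chlorophenyl gives an at least 2.2-fold higher number from compound 2 to compound 4 (0.34 log units; beyond the scatter), so this chloro weakens growth inhibition instead of strengthening it, and compound 2 stays the strongest of the four. The result for compound 4 is a limit, not a number: the limit of > 629000 nM in this assay, at which 1 of the 4 values shown sits. This is also the first change shown on this phenyl, as the earlier steps all altered the other phenyl, so it shows that a change on this ring can also move the value in this assay.

Going by these compounds, how far the true value of compound 4 lies past its limit remains unknown, so the full size of the loss cannot be read. On these data alone, whether fluoro or an amine in the same place on this ring would keep the activity of compound 2 also remains open.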